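A few compounds are considered here, and "the series" means these few. Any claim that something is new, unique, unknown or untested is made for them only; others in the source may bear on it.

Working notes on the series. The compounds share one core and differ in the group on the saturated chain carbon bound to the aromatic nitrogen. Compound 1 `CNC(=O)c1cc(C(=O)NC2CC2)c(C)n(Cc2ccccc2)c1=O` opens the set. In a physicochemical assay for solubility (on this read-out lower numbers stand for lower solubility and higher numbers for higher solubility), compound 1 gives >= 126 ug/mL, which is a limit of the assay and not a number. Compound 2 `CNC(=O)c1cc(C(=O)NC2CCC2)cn(Cc2cccnc2)c1=O` follows. In this assay compound 2 gives >= 99 ug/mL, again a limit. Compound 3 `CNC(=O)c1cc(C(=O)NC2CC2)cn(Cc2ccc3nc[nH]c3c2)c1=O` is the third member. In this assay compound 3 gives >= 163 ug/mL, also a limit. Compound 3 therefore stands only at a limit, and the two other values in this assay are limits as well, so no order among the three can be read; (the limit of >= 126 ug/mL in this assay, at which 1 of the 3 values shown sits), the limit of >= 163 ug/mL in this assay, at which 1 of the 3 values shown sits, and the limit of >= 99 ug/mL in this assay, at which 1 of the 3 values shown sits, each mark a ceiling rather than a measured point.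

Compound 4 `CNC(=O)c1cc(C(=O)NC2CC2)cn(Cc2ccc(OC)cc2)c1=O` is not yet measured. It differs from compound 3 by 4-methoxyphenyl in place of 1H-benzimidazol-6-yl on a saturated chain carbon bound to an aromatic nitrogen. Going by the values given here, no measured step between any two compounds is available, so the size of the change in this assay can only be expected. With every value of the series sitting at a ceiling, the expected step of an at least 1.3-fold lower number from compound 3 to compound 4 (0.13 log units; that floor lies within the scatter) is taken as none beyond the scatter. Compound 4 is expected to give 120 ug/mL, between 40 ug/mL and 200 ug/mL, with a fair chance that the assay again reports only a limit.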

Compound 4, solubility: >= 143 ug/mL
Compound 4: only a limit was reported; the forecaster's own chance of this, stated with the estimate: 60%; middle value at least 1.1-fold (0.07 log units) away from the limit.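

In this assay compound 4 gives >= 143 ug/mL, a limit of the assay and not a number. Going by these compounds alone, compound 3 gives >= 163 ug/mL, also a limit, so no step from compound 3 to compound 4 can be read. The compounds shown leave open whether 4-methoxyphenyl in place of 1H-benzimidazol-6-yl changes the read-out at all.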